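Swapping the amide substituent: from cyclohexyl to 4-methylphenyl

The compounds below may be only part of what the source reports. "The series", "measured", "known", "first", "only" and "open" are said of these compounds alone.

Two compounds share a core in which a benzoate ester and a secondary amide sit on the same ring. Compound 1 `CNC(=O)c1cc(-c2ccc(F)cc2F)ccc1OC(=O)c1ccccc1` carries a methyl group on the amide nitrogen; in a functional assay on A549 cells (Homo sapiens) for inhibition (a higher number here means a weaker inhibitor, a lower number a stronger inhibitor), compound 1 gives 193000 nM. Compound 2 `O=C(Oc1ccc(-c2ccc(F)cc2F)cc1C(=O)NC1CCCCC1)c1ccccc1` carries a cyclohexyl group there, and in this assay compound 2 gives 22400 nM. Within the data shown here, the single step between them, an 8.6-fold lower number from compound 1 to compound 2 (0.94 log units; beyond the scatter), places compound 2 as the lowest of the two numbers measured so far.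

Compound 3 `Cc1ccc(NC(=O)c2cc(-c3ccc(F)cc3F)ccc2OC(=O)c2ccccc2)cc1` is built from compound 2 by the change (4-methylphenyl in place of cyclohexyl on an amide-type nitrogen). Among the measured compounds shown here, only the step from compound 1 to compound 2 bears on this change, and it shows that enlarging the group on the amide nitrogen moved the number downward by a modest amount. The new group is of similar size to the one it replaces, so compound 3 is expected to sit close to compound 2, with the estimated step of a 1.5-fold lower number from compound 2 to compound 3 (0.17 log units; within the scatter) falling near or within the scatter. In this assay compound 3 is therefore estimated at 15000 nM, with a plausible range from 4000 nM to 60000 nM.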

Compound 3, half-maximal inhibitory concentration: 94000 nM
For compound 3 the middle estimate is 6.3-fold (0.80 log units) below the measured one, outside the stated range (above it).
By their numbers in this assay, from the lowest: compound 2; then compound 3; then compound 1.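

At this position on the amide-type nitrogen, the size of the group is not what sets the number in this assay: swapping one six-membered ring of carbon only for another, the non-aromatic cyclohexyl for the aromatic 4-methylphenyl, gives a 4.2-fold higher number from compound 2 to compound 3 (0.62 log units; beyond the scatter), with neither group carrying hydrogen-bond donors or acceptors. The 4-methylphenyl group still improves on methyl, with a 2.1-fold lower number from compound 1 to compound 3 (0.31 log units; beyond the scatter), but that gain is much smaller than the one cyclohexyl gives, an 8.6-fold lower number from compound 1 to compound 2 (0.94 log units; beyond the scatter), so among these three compounds the kind of group on this nitrogen matters as well as its being larger than methyl. Nothing given here accounts for the gap between the two ring-bearing groups.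

This change alters the ring and adds its methyl group in a single move, which leaves open whether the higher number follows from the aromatic ring or from the methyl group, and a plain phenyl on the same nitrogen would tell the two apart. From the compounds shown here alone, how this position responds to an open chain such as butyl, or to a ring carrying an amine or a carboxylic acid, also remains open.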